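This account rests on a few compounds, and the source may have more. Where it says the series, first, only, none or still open, it means among the compounds named here.

Measured so far in a physicochemical assay for lipophilicity, measured as octanol-water partition; a higher number here means a more lipophilic compound, a lower number a more polar compound:
- compound 1 `CCCCCCCCc1cn(C/C=C(/C)CCC=C(C)C)nn1` gives 6.92
- compound 2 `CCCc1cn(C/C=C(\C)CCC=C(C)C)nn1` gives 4.5
- compound 3 `CCCCCc1cn(C/C=C(\C)CCC=C(C)C)nn1` gives 5.45

Compound 2 has the lowest of the three numbers in this assay. Compound 3 is its nearest neighbour, and compound 1 lies furthest away at 6.92, well beyond the scatter.

The next compound to be measured is compound 4 `CCCc1cn(C/C=C(/C)CCC=C(C)C)nn1`. The change from compound 2 is as follows: the two compounds have the same atoms and bonds and differ only in configuration as drawn: 1 of 1 stereo elements differ; a double bond is drawn E in compound 2 and Z in compound 4. Nothing leaves and nothing enters, so the only question is what the drawn configuration of the double bond does to the number.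

Within the data shown here, only one measured step links two compounds that differ in one place: a number 0.95 log units higher from compound 2 to compound 3 (beyond the scatter). That step is a chain change, ethyl in place of hydrogen, and it leaves the double bond as drawn. Among the measured compounds shown here, it therefore gives no size for the present change, and no measured step isolates the configuration of the double bond. With the atoms and bonds unchanged, no shift of that modest size is foreseen, and no direction can be argued from these data.

The estimated change is no change at the digits printed from compound 2 to compound 4 (within the scatter), so no step beyond the scatter is expected. For compound 4 the expected value is 4.5, with an estimated range from 4.2 to 4.8.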

Compound 4, partition coefficient: 4.05
Estimate against measurement, compound 4: 0.45 log units above; measured number below the stated range.
By their numbers in this assay, from the lowest: compound 4; then compound 2; then compound 3; then compound 1.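

In this assay, the drawn configuration of the double bond is enough on its own to move the number: a number 0.45 log units lower from compound 2 to compound 4 (beyond the scatter). Among these compounds, the earlier compounds gave only a chain step, so this is the first reading for this double bond, and the shift can be assigned to it alone because of one structural fact: the fact that compounds 2 and 4 differ only in the configuration as drawn. Compound 4 also opens a chain comparison with the double bond drawn Z, hydrogen in place of pentyl, where a number 2.87 log units lower from compound 1 to compound 4 (beyond the scatter), and this runs the same way as the step with the double bond drawn E, where a number 0.95 log units higher from compound 2 to compound 3 (beyond the scatter).

Among the compounds shown here, only one pair of E and Z compounds stands here, so it remains open whether the shift keeps its size and direction on a longer chain, or with an amine or a carboxylic acid on the chain. The numbers give the size and direction of this one shift but no mechanism for it.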